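Phenyl to Vinyl on a Chloro-Substituted Core

The source may hold more compounds than are shown below. What is called first, only, known or untested is meant among the compounds shown, and "the series" means these compounds.

In a functional assay on RKO cells (Homo sapiens) for cytotoxicity, read by MTT assay, with a stated time of 48 h (on this read-out higher numbers stand for weaker inhibition and lower numbers for stronger inhibition), compound 2 `Clc1ccnc2cc(OCc3ccccc3)ccc12` gives 2410 nM, level with compound 3 `Fc1ccc(COc2ccc3c(Cl)ccnc3c2)cc1` at 1980 nM, while compound 1 `CN(C)CCNc1ccnc2cc(OCc3ccc(F)cc3)ccc12` gives a clearly lower 580 nM. Compound 4 `C=CCOc1ccc2c(Cl)ccnc2c1` differs from compound 2 by vinyl in place of phenyl on a saturated chain carbon bound to an oxygen on an aromatic ring. Fluoro in place of hydrogen on an aromatic carbon gave a 1.2-fold lower number from compound 2 to compound 3 (0.09 log units; within the scatter), but that step leaves the phenyl in place. Chloro in place of (2-(dimethylamino)ethyl)amino gave a 3.4-fold higher number from compound 1 to compound 3 (0.53 log units; beyond the scatter), a change elsewhere in the molecule. Neither step removes the phenyl, so the data offer only weak guidance, and a modest rise in this assay is expected. The estimated change is a 1.6-fold higher number from compound 2 to compound 4 (0.20 log units; within the scatter). For compound 4 the expected value is 3800 nM, within an estimated range of 1600 nM to 9000 nM.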

Compound 4, half-maximal inhibitory concentration: 2460 nM
Compound 4: the middle estimate sits 1.5-fold (0.19 log units) above what was measured, within the range that was stated.
By their numbers in this assay, from the lowest: compound 1; then compounds 3, 2 and 4 (each within the scatter of the next).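

In this assay there is a 1.0-fold higher number from compound 2 to compound 4 (0.01 log units; within the scatter) when vinyl replaces phenyl. The earlier compounds shown here only added fluoro to that phenyl, whereas here the whole aromatic ring goes and compound 2 and compound 4 still stand level, so on this chloro-bearing core the ring is not needed to hold this level. No measurement here explains why the two groups read alike. As far as these compounds go, whether this also holds with (2-(dimethylamino)ethyl)amino in place of chloro remains open. So does the effect of a longer saturated chain, an amine or a carboxylic acid at this place.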